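Swapping the methanesulfonamido of compound 1 for an oxazole

The source may hold more compounds than are shown below. What is called first, only, known or untested is meant among the compounds shown, and "the series" means these compounds.

The account starts from compound 1 `CS(=O)(=O)Nc1cccc2c1CCC2c1ncc[nH]1` in a functional assay on CHO cells for agonist activity at Alpha-1D adrenergic receptor (Homo sapiens), read by FLIPR and calcium flux; a lower number here means that less compound is needed, a higher number that more compound is needed for the effect. In this assay compound 1 returns only a limit, > 10000 nM. Two companions set the background. Compound 2 `Cc1c(OCC2=NCCN2)ccc(Cl)c1NS(C)(=O)=O` also stops at a limit in this assay, > 10000 nM. Compound 3 `Cn1ccc(-c2cccc3c2CCC3c2ncc[nH]2)n1` differs from compound 1 in one place; in this assay compound 3 likewise gives a limit, > 10000 nM. For the measured compounds named here, the one measured step, a step that the two limits leave unreadable from compound 1 to compound 3, therefore cannot be sized, and the whole picture is summarised by the limit of > 10000 nM in this assay, at which 3 of the 3 values shown sit.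

The new compound, compound 4 `c1cc(-c2ncco2)c2c(c1)C(c1ncc[nH]1)CC2`, is reached from compound 1 by 1,3-oxazol-2-yl in place of methanesulfonamido on an aromatic carbon. Going by the values given here, the only step that bears on this change is the one from compound 1 to compound 3, which shares the replacement of the methanesulfonamido by a five-membered aromatic group and which both limits leave unreadable. Among the compounds with values here, no measured step gives a size or a direction, so no movement beyond the scatter is expected, and the most likely outcome is that compound 4 again sits at the limit of this assay. For compound 4 the estimate is 15000 nM, between 3000 nM and 60000 nM, which corresponds to an expected step that the limit leaves unreadable from compound 1 to compound 4.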

Compound 4, half-maximal effective concentration: 1390 nM
The estimate for compound 4 lay 11-fold (1.03 log units) above the measured number; the whole stated range lies above it.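

For the compounds shown here, replacing the methanesulfonamido with 1,3-oxazol-2-yl on this aromatic carbon of the shared core gives the first readable change in this assay, namely an at least 7.1-fold lower number from compound 1 to compound 4 (0.85 log units; beyond the scatter) and so shows that this position can respond to the group it carries. A five-membered aromatic ring at this carbon is not enough in itself, for compound 3 gives only the limit > 10000 nM as its result. The choice of ring matters here, with an at least 7.1-fold lower number from compound 3 to compound 4 (0.85 log units; beyond the scatter) between the 1-methyl-1H-pyrazol-3-yl and the 1,3-oxazol-2-yl, and compound 4 alone moves off the limit shared by the other compounds: the limit of > 10000 nM in this assay, at which 3 of the 4 values shown sit.

Both readable steps start from a limit, so their full size stays open, and the compounds shown do not tell which feature of the 1,3-oxazol-2-yl carries the change. Also open, on these data alone, is how other groups at this carbon, such as an amine, a carboxylic acid or a 1,3-thiazol-2-yl, would compare with the 1,3-oxazol-2-yl of compound 4.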